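This account rests on a few compounds, and the source may have more. Where it says the series, first, only, none or still open, it means among the compounds named here.

Measured compounds:
compound 1 `COc1ccc(N(CC(=O)NCCC[Se]c2ccccc2)C(=O)c2ccccc2)cc1`
compound 2 `COc1ccc(N(CC(=O)NCCC[Te]c2ccccc2)C(=O)/C=C/c2ccccc2)cc1`
compound 3 `COc1ccc(N(CC(=O)NCCC[Se]c2ccccc2)C(=O)/C=C/c2ccccc2)cc1`

In an ADME assay on cells (Fibroblast, Homo sapiens) for cytotoxicity, read by MTT assay, with a stated time of 24 h (on this read-out lower numbers stand for stronger inhibition and higher numbers for weaker inhibition), compound 1 gives >= 100000 nM, which is a limit of the assay and not a number. Compound 3 gives >= 100000 nM in this assay, again a limit. Compound 2 gives 5000 nM in this assay. Compound 3 thus stands at the ceiling of the numbers shown, together with the limit of >= 100000 nM in this assay, at which 2 of the 3 values shown sit. The step that the two limits leave unreadable from compound 1 to compound 3 shows that exchanging the group on the carbonyl carbon between the two selenium-bearing compounds gives nothing readable. The step of an at least 20-fold higher number from compound 2 to compound 3 (1.30 log units; beyond the scatter) shows that the selenium group in place of the tellurium group moves the number far up, out of the measurable range.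

Compound 4 `COc1ccc(N(CC(=O)NCCC[Se]c2ccccc2)C(=O)CNC(=O)OC(C)(C)C)cc1` keeps the selenium-bearing chain of compound 3 and differs only at the carbonyl: ((tert-butoxycarbonyl)amino)methyl in place of 2-phenylethenyl on a carbonyl carbon. For the measured compounds named here, the one step that bears on this change is a step that the two limits leave unreadable from compound 1 to compound 3, and it shows no readable change; no measured step shows a group on that carbonyl carbon bringing a selenium compound below the ceiling. The expectation for compound 4 in this assay is thus a number at or near the ceiling again, with a number no higher from compound 3 to compound 4 (the limit leaves the size open) expected within the scatter. The estimate for compound 4 is 100000 nM, with a range from 50000 nM to 300000 nM, most likely reported only as a limit.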

Compound 4, half-maximal inhibitory concentration: >= 100000 nM
Compound 4: no number, only a limit; the forecaster's own chance of this, stated with the estimate: 75%; the middle value lies on the limit itself.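

In this assay compound 4 gives >= 100000 nM, a limit of the assay and not a number, so the steps linking compound 4 with compound 1 and compound 3 cannot be read: the limit of >= 100000 nM in this assay, at which 3 of the 4 values shown sit.

The compounds shown leave open how far compound 1, compound 3 and compound 4 actually differ, and whether the group on the carbonyl carbon matters at all in this series.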